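Combretastatin-type stilbenes: benzyl ether tail variation

The source may hold more compounds than are shown below. What is called first, only, known or untested is meant among the compounds shown, and "the series" means these compounds.

Working notes on the series. Of the compounds shown here, two carry numbers so far in a functional assay on HeLa cells (Homo sapiens) for antiproliferative activity, read by CCK-8 assay, with a stated time of 48 h; on this read-out lower numbers stand for stronger inhibition and higher numbers for weaker inhibition. Compound 1 `COc1ccc(/C=C\c2cc(OC)c(OC)c(OC)c2)cc1OCc1ccc(CN2CC[C@@H](C(=O)O)C2)cc1` bears a (3-carboxypyrrolidin-1-yl)methyl group on the benzyl ether ring and in this assay compound 1 gives 12800 nM. Compound 2 `COc1ccc(/C=C\c2cc(OC)c(OC)c(OC)c2)cc1OCc1ccc(C=O)cc1` carries a formyl group in that place and in this assay compound 2 gives 4800 nM. Among the measured compounds shown here, the only step so far, a 2.7-fold lower number from compound 1 to compound 2 (0.43 log units; beyond the scatter), puts compound 2 at the lowest of the two numbers, with compound 1 as its nearest neighbour.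

Compound 3 `COc1ccc(/C=C\c2cc(OC)c(OC)c(OC)c2)cc1OCc1ccc(CNCCO)cc1` differs from compound 2 as follows: ((2-hydroxyethyl)amino)methyl in place of formyl on an aromatic carbon. For the measured compounds named here, the one measured step bears on this change in a loose way only: both compound 1 and compound 3 carry an amine-bearing methyl tail in place of the formyl, and that step, a 2.7-fold lower number from compound 1 to compound 2 (0.43 log units; beyond the scatter), ran toward a higher number when the formyl was replaced. The tail of compound 3 is smaller and uncharged compared with that of compound 1, so a step in the same direction but of smaller size is expected in this assay, a 1.7-fold higher number from compound 2 to compound 3 (0.22 log units; within the scatter), plausibly within or just beyond the scatter. Compound 3 is therefore estimated at 8000 nM, with a range from 3000 nM to 25000 nM.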

Compound 3, half-maximal inhibitory concentration: 4400 nM
For compound 3 the middle estimate is 1.8-fold (0.26 log units) above the measured one, and the stated range covers the measured number.
By their numbers in this assay, from the lowest: compounds 3 and 2 (each within the scatter of the next); then compound 1.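

In this assay, ((2-hydroxyethyl)amino)methyl in place of formyl, on the aromatic carbon para to a large group, gives a 1.1-fold lower number from compound 2 to compound 3 (0.04 log units; within the scatter), so at this position the larger amine-bearing tail of 5 heavy atoms and the formyl of 2 heavy atoms cannot be told apart. The comparison of the two amine-bearing tails gives a 2.9-fold lower number from compound 1 to compound 3 (0.46 log units; beyond the scatter), which shows that the higher number of compound 1 is not common to both tails and, among the three compounds, belongs only to the 3-carboxypyrrolidin-1-yl tail. No measurement at hand accounts for either result.

The compounds shown leave open whether the gap to compound 1 follows the carboxylic acid or the pyrrolidine ring, a question that a plain pyrrolidin-1-ylmethyl group or an open-chain (2-carboxyethyl)aminomethyl group would bear on directly. They also leave open how far the tail of compound 3 can change, for instance with a longer chain such as (3-hydroxypropyl)aminomethyl or with a methyl ether in place of the terminal hydroxyl.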